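The source may hold more compounds than are shown below. What is called first, only, known or untested is meant among the compounds shown, and "the series" means these compounds.

Measured so far in a functional assay on NCI-H460 cells (Homo sapiens) for cytotoxicity, read by MTT assay, with a stated time of 24 h; on this read-out lower numbers stand for stronger inhibition and higher numbers for weaker inhibition:
Compound 1 `C=CCn1c(=O)c(C=O)cc2ccccc21`: > 100000 nM (limit)
Compound 2 `C#CCn1c(=O)c(C=O)cc2cc(OC)ccc21`: > 100000 nM (limit)
Compound 3 `C#CCn1c(=O)c(/C=C/C(=O)/C=C(O)/C=C/c2ccc(O)c(OC)c2)cc2cc(OC)ccc21`: 38100 nM

For the measured compounds named here, compound 3 carries the only number in the set, 38100 nM. The results for compound 1 and compound 2 are limits of the assay, not numbers. Compound 4 `C#CCn1c(=O)c(/C=C/C(=O)/C=C(O)/C=C/c2ccc(O)c(OC)c2)cc2cc(F)ccc21` differs from compound 3 by one change: fluoro in place of methoxy on an aromatic carbon. It has fluoro in place of methoxy on an aromatic carbon. Going by the values given here, no measured pair shows this change, so the expectation rests on compound 3 at 38100 nM. In this assay no step beyond the scatter is expected, and neither direction is favoured. The estimated step is a 1.1-fold lower number from compound 3 to compound 4 (0.02 log units; within the scatter). For compound 4 the estimated value is 36000 nM, with an expected range of 13000 nM to 95000 nM.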

Compound 4, half-maximal inhibitory concentration: 44300 nM
The estimate for compound 4 lay 1.2-fold (0.09 log units) below the measured number; the range from low to high includes it.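

Fluoro in place of methoxy on an aromatic carbon gives, in this assay, a 1.2-fold higher number from compound 3 to compound 4 (0.07 log units; within the scatter). This position, meta to a fused ring and para to a fused ring, therefore takes either group without a step beyond the scatter, even though the change removes a hydrogen-bond acceptor and a heavy atom. No measured property offers a reason for this result.

Going by these compounds, whether an amine or a carboxylic acid at this position would give a similar number remains open. Steps involving compound 1 and compound 2, whose results are limits of the assay, cannot be read.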